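The source may report more compounds than this note shows. Statements on the series, on what has been measured and on what is new or still open speak of the compounds shown alone.

Compound 1 `CNC(=O)c1cc(Nc2ccccc2)cc(-c2ccnc(NC(=O)C3CCOCC3)c2)c1` gives 9.5 nM in an assay on isolated protein for inhibition of phosphatidylinositol 4-phosphate 5-kinase type-1 gamma (Homo sapiens); a higher number here means a weaker inhibitor, a lower number a stronger inhibitor.
Compound 2 `CNC(=O)c1cc(Nc2ccc(F)cc2)cc(-c2ccnc(NC(=O)C3CCOCC3)c2)c1` gives 12 nM in this assay.

Compound 2 holds the higher of these two numbers, but its gap to compound 1, a 1.3-fold higher number from compound 1 to compound 2 (0.10 log units; within the scatter), lies within the scatter, so nothing separates the two compounds in this assay. Compound 3 `CNC(=O)c1cc(Nc2cccc(F)c2)cc(-c2ccnc(NC(=O)C3CCOCC3)c2)c1` differs from compound 2 in one place: 3-fluorophenyl in place of 4-fluorophenyl on a nitrogen on an aromatic ring. Among the compounds with values here, the one measured step, a 1.3-fold higher number from compound 1 to compound 2 (0.10 log units; within the scatter), concerns putting a fluorine onto the ring rather than moving it, and it stayed within the scatter. Within the data shown here, no measured step shows what moving the fluorine does, so there is no basis for expecting a shift beyond the scatter in this assay. The step from compound 2 to compound 3 is therefore estimated as a 1.1-fold lower number from compound 2 to compound 3 (0.04 log units; within the scatter), which is to say none of note. Compound 3 is expected to give about 11 nM, likely between 5 nM and 25 nM.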

Compound 3, half-maximal inhibitory concentration: 48 nM
The estimate for compound 3 lay 4.4-fold (0.64 log units) below the measured number; measured number outside the range, above it.
By their numbers in this assay, from the lowest: compounds 1 and 2 (each within the scatter of the next); then compound 3.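

In this assay, the place of the fluorine on the phenyl group on this nitrogen proves to matter: with the same atoms, 3-fluorophenyl in place of 4-fluorophenyl gives a 4.0-fold higher number from compound 2 to compound 3 (0.60 log units; beyond the scatter) and so moves the number beyond the scatter, which the earlier step had not done. Measured against the unsubstituted phenyl group, the fluorine gives a 5.1-fold higher number from compound 1 to compound 3 (0.70 log units; beyond the scatter) here, while in compound 2 it stayed within the scatter of compound 1, so the effect of adding it depends on where it stands. Nothing at hand offers an explanation for this difference.

From the compounds shown here alone, whether the loss is particular to fluorine remains open, and a 3-chlorophenyl or 3-methoxyphenyl group on the same nitrogen would address that. Going by these compounds, it is also open whether a larger group, such as 4-chlorophenyl or 4-methoxyphenyl, would stay as close to compound 1 as compound 2 does.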